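The source may hold more compounds than are shown below. What is called first, only, known or untested is meant among the compounds shown, and "the series" means these compounds.

The measured compounds are:

compound 1, `ClCc1cccc(Cn2cnc3ncnc(Cl)c32)c1`: 2040 nM
compound 2, `ClCc1cccc(Cn2cnc3c(Cl)ncnc32)c1`: 2290 nM
compound 3, `ClCc1cccc(Cn2cnc3c(Cl)nc(Cl)nc32)c1`: 750 nM

All three were tested in a functional assay on RXF 393 cells (Homo sapiens) for cytotoxicity, read by sulforhodamine B assay, with a stated time of 48 h; on this read-out lower numbers stand for stronger inhibition of growth and higher numbers for weaker inhibition of growth. Compound 1 and compound 2 are built from the same atoms joined differently; the difference between their two cores is not broken down here. Their two values lie within the usual scatter of each other, so nothing can be said about an order between them. Among the compounds with values here, compound 3 is derived from compound 2 by chloro in place of hydrogen on an aromatic carbon and this change produced a 3.1-fold lower number from compound 2 to compound 3 (0.48 log units; beyond the scatter), the one step in this set that clearly lies beyond the scatter.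

Compound 4, `ClCc1cccc(Cn2cnc3nc(Cl)nc(Cl)c32)c1`, has not yet been measured in this assay. It is derived from compound 1 by chloro in place of hydrogen on an aromatic carbon. Within the data shown here, the place where the chloro enters is described in the same words for both pairs, so this is the same change as the one from compound 2 to compound 3, applied to the other core. Because the earlier instance gave a 3.1-fold lower number from compound 2 to compound 3 (0.48 log units; beyond the scatter), compound 4 is expected to show a step of similar size, estimated as a 3.1-fold lower number from compound 1 to compound 4 (0.49 log units; beyond the scatter). Among the measured compounds shown here, since only one measured instance of this change is available, the expected range for compound 4 is kept wide. The expected value of compound 4 in this assay is 660 nM, estimated to fall between 300 nM and 1500 nM.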

Compound 4, concentration for 50% growth inhibition: 1340 nM
Beside the measured number, compound 4's estimate is 2.0-fold (0.31 log units) below it; the range from low to high includes it.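

In this assay, chloro in place of hydrogen on an aromatic carbon, between two ring nitrogen atoms, gave a 1.5-fold lower number from compound 1 to compound 4 (0.18 log units; within the scatter), so on the core of compound 1 the step cannot be told apart from repeated-measurement noise. Set beside the earlier instance on the other core, the two steps do not differ by more than the scatter allows: the same change on two cores in this assay, a 3.1-fold lower number (0.48 log units; beyond the scatter) from compound 2 to compound 3 and a 1.5-fold lower number (0.18 log units; within the scatter) from compound 1 to compound 4, 2.0-fold (0.30 log units) apart, within the scatter of two such steps This shows that the results are compatible with the change carrying over from one core to the other, but it does not show that the step has the same size on both, nor that the core alters it, since each core offers a single pair and only one of the two steps stands clear of the scatter.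

The compounds shown carry only hydrogen or chloro at this place, so it remains open how an amine, a methoxy group or a longer chain there would behave on either core. They also all keep the chloromethyl group, which leaves open how far the values in this assay would hold if a hydroxymethyl group or a plain methyl group stood in its place.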